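The compounds below may be only part of what the source reports. "The series", "measured", "known", "first", "only" and "open" are said of these compounds alone.

Within the data shown here, compound 2 `Cc1cc(NC(=O)Nc2ccc(C(F)(F)F)cc2)c2ccccc2n1` is one of two compounds measured in a physicochemical assay for solubility, at pH 7.4; a lower number here means a less soluble compound, a higher number a more soluble compound. Compound 1 `Cc1ccc(NC(=O)Nc2cc(C)nc3ccccc23)cc1` gives 1300 nM there, while compound 2 gives 100 nM, so compound 2 stands as the lower of the two numbers. Among the measured compounds shown here, the single step between them, a 13-fold lower number from compound 1 to compound 2 (1.11 log units; beyond the scatter), is the only measured step in the set, and it followed a change of trifluoromethyl in place of methyl on an aromatic carbon.

Compound 3 `Cc1cc(NC(=O)Nc2ccc(C(=O)O)cc2)c2ccccc2n1` is not yet measured in this assay. It differs from compound 2 in one place: carboxy in place of trifluoromethyl on an aromatic carbon.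

For the measured compounds named here, no measured step introduces or removes a carboxy group, so the available data bear on this change only indirectly: the one recorded step shows that the group at this position on compound 2 can move the number by a large amount, and compound 3 removes exactly the group whose entry coincided with the drop. Compound 3 is therefore expected to show a rise of a 40-fold higher number from compound 2 to compound 3 (1.60 log units; beyond the scatter) relative to compound 2, beyond the scatter. The estimated value for compound 3 in this assay is 4000 nM, within a range from 600 nM to 30000 nM.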

Compound 3, solubility: 9300 nM
Beside the measured number, compound 3's estimate is 2.3-fold (0.37 log units) below it; the measured number falls inside the stated range.
By their numbers in this assay, from the lowest: compound 2; then compound 1; then compound 3.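

In this assay the replacement of trifluoromethyl by carboxy gives a 93-fold higher number from compound 2 to compound 3 (1.97 log units; beyond the scatter) on this six-membered aromatic ring of carbon only, so a place that had so far shown only a fall now shows a rise, and a larger one than that fall. The change does more than cancel the earlier drop: carboxy in place of methyl gives a 7.2-fold higher number from compound 1 to compound 3 (0.85 log units; beyond the scatter) as well, so the three groups at this one place now form an order, with trifluoromethyl lowest, methyl in the middle and carboxy highest, every step between them beyond the scatter. No independent measurement is available to explain why these groups fall in this order.

The compounds shown leave open whether the high number belongs to the carboxylic acid itself or would also come with a methyl ester, a primary amide, an amine or a hydroxy group at the same place. They also leave open whether carboxy would give a rise of similar size elsewhere on this ring or on a different core.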